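The source may hold more compounds than are shown below. What is called first, only, known or untested is meant among the compounds shown, and "the series" means these compounds.

Compound 1 `Cc1cc(C(=O)O)nn1Cc1cc(Br)ccc1OCc1ccc(Cl)cc1` is the reference point. In a functional assay on CHO-K1 cells for antagonist activity at prostaglandin E2 receptor EP1 subtype (Homo sapiens), read by FLIPR (on this read-out lower numbers stand for stronger inhibition and higher numbers for weaker inhibition), compound 1 gives 8.71 nM, the lowest of the three measured numbers. Compound 2 `Cc1cc(C(=O)O)nn1Cc1cc(Br)ccc1OCc1ccc(C(F)(F)F)cc1` gives 97.7 nM and compound 3 `Cc1cc(C(=O)O)nn1Cc1cc(Br)ccc1OCc1cccc([N+](=O)[O-])c1` gives 339 nM. The step to compound 4 `Cc1cc(C(=O)O)nn1Cc1cc(Br)ccc1OCc1ccc(Cl)c(C(F)(F)F)c1` is trifluoromethyl in place of hydrogen on an aromatic carbon, on an aromatic carbon of a six-membered aromatic ring of carbon only, ortho to a chloro group and meta to a large group. The step of an 11-fold higher number from compound 1 to compound 2 (1.05 log units; beyond the scatter) swapped that chloro for trifluoromethyl; the step of a 39-fold higher number from compound 1 to compound 3 (1.59 log units; beyond the scatter) replaced the whole ring. Both went toward higher numbers. Compound 4 is therefore expected to show a 4.0-fold higher number from compound 1 to compound 4 (0.60 log units; beyond the scatter) in this assay, a moderate rise. The estimate for compound 4 is 35 nM, within 8 nM to 150 nM.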

Compound 4, inhibition constant: < 2000 nM
Compound 4: no number, only a limit; the forecaster's own chance of this, stated with the estimate: 3%; the middle value is on the limit's open side.
By their numbers in this assay, from the lowest: compound 1; then compound 2; then compound 3.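

Among these compounds, compound 4 gives only a limit of < 2000 nM and not a number, so no step from compound 1 to compound 4 can be read. Going by these compounds, whether adding trifluoromethyl raises or lowers the number in this assay stays open.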